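The source may report more compounds than this note shows. Statements on the series, on what has been measured and on what is new or still open speak of the compounds shown alone.

Among the compounds with values here, compound 2 `COc1cc2nc(/C=C/c3ccccc3F)nc(N3CCC(CCNS(N)(=O)=O)CC3)c2cc1OC` is one of two compounds measured in an assay on cells for inhibition of Ectonucleotide pyrophosphatase/phosphodiesterase family member 1 (Homo sapiens), with a stated time of 60 min, tested at 1 uM; a higher number here means more inhibition at the concentration tested (going by the name of the read-out), a lower number less inhibition. In this assay compound 2 gives 78%, the lower of the two numbers. Within the data shown here, its only neighbour, compound 1 `COc1cc2nc(/C=C/c3cccnc3)nc(N3CCC(CCNS(N)(=O)=O)CC3)c2cc1OC`, gives 86%, and the step of a number 8 percentage points lower from compound 1 to compound 2 (within the scatter) lies within the scatter, so the two compounds cannot be told apart on these numbers. Compound 3 `COc1cc2nc(/C=C/c3ccc(F)cc3)nc(N3CCC(CCNS(N)(=O)=O)CC3)c2cc1OC` is built from the same atoms as compound 2, joined differently: 4-fluorophenyl in place of 2-fluorophenyl on a double-bonded chain carbon bound to a double-bonded chain carbon. Among the measured compounds shown here, only one measured step touches this place on the chain, and that step, a number 8 percentage points lower from compound 1 to compound 2 (within the scatter), exchanged a whole ring rather than one fluorophenyl for another, and it stayed within the scatter. For the measured compounds named here, no measured step compares 2-fluorophenyl with 4-fluorophenyl directly. Going by the values given here, with the one related step inside the scatter, the expected step of no change at the digits printed from compound 2 to compound 3 (within the scatter) is none beyond the scatter. Compound 3 is therefore estimated to give about 78%, within a range from 64% to 90%.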

Compound 3, a percentage reported as inhibition, at one concentration (the size of the read-out at that concentration, not a potency): 70%
Compound 3: middle estimate off by 8 percentage points, on the high side, and the stated range covers the measured number.
By their numbers in this assay, from the lowest: compounds 3, 2 and 1 (each within the scatter of the next, the first and the last beyond it).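

Measured in this assay the swap of 2-fluorophenyl for 4-fluorophenyl gives a number 8 percentage points lower from compound 2 to compound 3 (within the scatter) and so does not separate these two rings at this place on the chain. Within the data shown here, the other new comparison gives a number 16 percentage points lower from compound 1 to compound 3 (beyond the scatter) and is the first step at this position to clear the scatter, showing a modest but readable difference between pyridin-3-yl and 4-fluorophenyl, while 2-fluorophenyl cannot be told apart from either. Nothing available explains this difference.

From the compounds shown here alone, how a plain phenyl, pyridin-2-yl or pyridin-4-yl would read at this place remains open. Going by these compounds, a percentage at one concentration is also not a potency, so the size of the gap in potency between the pyridin-3-yl and 4-fluorophenyl compounds is unknown.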